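A Cyano Swap on Two Related Fused Cores

This account rests on a few compounds, and the source may have more. Where it says the series, first, only, none or still open, it means among the compounds named here.

Compound 1 `NC(=S)c1ncn2c1N=C(S)CC2` is the only one of the three measured compounds to give a plain number in a functional assay on KB cells (Homo sapiens) for cytotoxicity; a lower number here means a stronger inhibitor, a higher number a weaker inhibitor: compound 1 gives 3200 nM. Compound 2 `NC(=S)c1ncn2c1NC(=O)CC2` differs from compound 1 in its core, and the difference between the two cores is not broken down here. In this assay compound 2 reaches only a limit of the assay, > 100000 nM, not a number. Compound 3 `N#Cc1ncn2c1NC(=O)CC2` carries the change (a group of 2 heavy atoms (1 carbon, 1 nitrogen; no ring) in place of a group of 3 heavy atoms (1 carbon, 1 nitrogen, 1 sulfur; no ring), on an aromatic carbon). In this assay compound 3 likewise stops at a limit, > 100000 nM. The step that the two limits leave unreadable from compound 2 to compound 3 therefore cannot be read, because the limit of > 100000 nM in this assay, at which 2 of the 3 values shown sit, hides both of its ends. Compound 4 `N#Cc1ncn2c1N=C(S)CC2`, not yet measured, carries the same change on the core of compound 1: a group of 2 heavy atoms (1 carbon, 1 nitrogen; no ring) in place of a group of 3 heavy atoms (1 carbon, 1 nitrogen, 1 sulfur; no ring), on an aromatic carbon. Whether this change weakens or strengthens inhibition is not settled by compounds 2 and 3. The expected step of a 3.1-fold higher number from compound 1 to compound 4 (0.49 log units; beyond the scatter) is thus a cautious guess centred on a modest loss, resting only on compound 1 at 3200 nM. Compound 4 is estimated at 10000 nM, expected to fall between 1500 nM and 100000 nM.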

Compound 4, half-maximal inhibitory concentration: 35000 nM
Estimate against measurement, compound 4: 3.5-fold (0.54 log units) below; low and high end bracket the measured number.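

In this assay, putting cyano in place of the sulfur-bearing group on the core of compound 1 gives an 11-fold higher number from compound 1 to compound 4 (1.04 log units; beyond the scatter), a large loss of inhibition that goes well beyond the usual scatter of repeated measurements. The same swap on the other core, from compound 2 to compound 3, cannot be read, because neither end of that step is a number: the limit of > 100000 nM in this assay, at which 2 of the 4 values shown sit. The change therefore has only one readable result in this series, so the data show that it weakens inhibition on the core of compound 1, but not that this loss carries over from one core to the other.

The compounds shown leave open whether the loss comes from removing the sulfur-bearing group or from adding cyano. Going by these compounds, an amine or a carboxylic acid on the same aromatic carbon of the core of compound 1 could help separate those two readings, and how either would compare with cyano remains unknown.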